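The source may hold more compounds than are shown below. What is called first, only, known or untested is meant among the compounds shown, and "the series" means these compounds.

Three compounds from this study were tested in a functional assay on the whole organism (artery, strain albino) with Rattus norvegicus as the target, with a stated time of 720 min, at a dose of 10 mg/kg by the oral route; on this read-out lower numbers stand for less inhibition and higher numbers for more inhibition at the one dose given (going by the name of the read-out). Compound 1, with the structure `COc1ccc(C2N=C(SCc3ccccc3Cl)NC(C)=C2C(=O)Nc2ccc(F)cc2)cc1OC`, gives 23.2% in this assay. Compound 2, whose structure is `COc1ccc(C2N=C(SCc3cccc(Cl)c3)NC(C)=C2C(=O)Nc2ccc(F)cc2)cc1OC`, gives 15.5%. The two differ only by 3-chlorophenyl in place of 2-chlorophenyl on a saturated chain carbon bound to a sulfur, and that change made a step of a number 7.7 percentage points lower from compound 1 to compound 2 (within the scatter). Compound 3, with the structure `CC1=C(C(=O)Nc2ccc([N+](=O)[O-])cc2)C(c2ccc(Br)cc2)N=C(SCc2ccccc2Cl)N1`, gives 6.7%; the difference between its core and the core of compound 1 is not broken down here, and the two values simply show that compound 3 sits well under compound 1, while its distance from compound 2 lies within the scatter.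

Compound 4, whose structure is `CC1=C(C(=O)Nc2ccc([N+](=O)[O-])cc2)C(c2ccc(Br)cc2)N=C(SCc2cccc(Cl)c2)N1`, has not yet been measured. It differs from compound 3 by 3-chlorophenyl in place of 2-chlorophenyl on a saturated chain carbon bound to a sulfur, at the same place, so it is the same change that carries compound 1 to compound 2. Since that earlier step was a number 7.7 percentage points lower from compound 1 to compound 2 (within the scatter) and counted as within the scatter, compound 4 is expected to move from compound 3 by about a number 3.7 percentage points lower from compound 3 to compound 4 (within the scatter), an estimate that rests on that one pair alone. Compound 4 is therefore estimated to give 3% in this assay, with a likely range from -6% to 14%.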

Compound 4, a percentage reported as inhibition, in the whole organism at one dose (the size of the read-out at that dose, not a potency): 2.6%
For compound 4 the middle estimate is 0.4 percentage points above the measured one, and the stated range covers the measured number.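

In this assay, the change from 2-chlorophenyl to 3-chlorophenyl on a saturated chain carbon bound to a sulfur, carried onto the core of compound 3, comes to a number 4.1 percentage points lower from compound 3 to compound 4 (within the scatter). Set beside the step on the core of compound 1, the change reads alike on both cores, with steps that point the same way and cannot be told apart in size: the same change on two cores in this assay, a number 7.7 percentage points lower (within the scatter) from compound 1 to compound 2 and a number 4.1 percentage points lower (within the scatter) from compound 3 to compound 4, 3.6 percentage points apart, within the scatter of two such steps This shows that nothing in these two pairs speaks against carrying the change from one core to the other, but it does not show that the change has a real effect on either core, since each step on its own lies within the scatter, and two cores at a single oral dose are too few to support a rule for the series.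

The compounds shown leave open what happens when the chlorine on that ring gives way to a fluorine, a methyl or a methoxy group, or when a longer chain takes the place of the benzyl group on the sulfur. They also leave open whether an amine or a carboxylic acid on the aryl ring of the amide would change the picture, and how any of these compounds would behave at other doses.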